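Amide variation on the shared core: outlook for compound 3

The source may hold more compounds than are shown below. What is called first, only, known or untested is meant among the compounds shown, and "the series" means these compounds.

For the measured compounds named here, compound 2 `CN(C)CCC(=O)Nc1cccc(-c2nc3ccccc3s2)c1` is the only member of the series with a number in an ADME assay on HepG2 cells (Homo sapiens) for inhibition, with a stated time of 72 h (a lower number here means that less compound is needed, a higher number that more compound is needed for the effect), where compound 2 gives 21000 nM. Compound 1 `C/C=C/C(=O)Nc1cccc(-c2nc3ccccc3s2)c1` has no number in this assay; its value > 25000 nM is a limit of the assay. Going by the values given here, the single measured step, an at least 1.1-fold lower number from compound 1 to compound 2 (0.07 log units; that floor lies within the scatter), runs from that limit to the one number, and the change there is on a carbonyl carbon. Compound 3 `O=C(Nc1cccc(-c2nc3ccccc3s2)c1)c1cccnc1Cl` alters the same position: 2-chloropyridin-3-yl in place of 2-(dimethylamino)ethyl on a carbonyl carbon. Among the compounds with values here, only the step from compound 1 to compound 2 bears on this, and it sits at the scatter floor, so no step beyond the scatter is expected in this assay in either direction. Given (the limit of > 25000 nM in this assay, at which 1 of the 2 values shown sits), compound 3 is expected at 20000 nM, within 5000 nM to 80000 nM, a step of a 1.1-fold lower number from compound 2 to compound 3 (0.02 log units; within the scatter), with a fair chance that only a limit is reported.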

Compound 3, half-maximal effective concentration: > 25000 nM
Compound 3 was reported as a limit; the forecaster's own chance of this, stated with the estimate: 40%; middle value at least 1.2-fold (0.09 log units) from the limit.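

In this assay compound 3 gives > 25000 nM, which is a limit of the assay and not a number. Setting 2-chloropyridin-3-yl in place of 2-(dimethylamino)ethyl on a carbonyl carbon gives an at least 1.1-fold higher number from compound 2 to compound 3 (0.07 log units; that floor lies within the scatter), so a group with an aromatic ring at this place yields only a floor for the step, and that floor does not leave the scatter. The step between compound 1 and compound 3 cannot be read, and this position now gives mostly limits rather than numbers: the limit of > 25000 nM in this assay, at which 2 of the 3 values shown sit.

For the compounds shown here, compound 2 at 21000 nM remains the only number, so how far compound 3 lies from it stays open. Also open, on these data alone, is whether a longer amine chain or a carboxylic acid on this carbonyl carbon would give a number in this assay clearly apart from that of compound 2.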